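The source may hold more compounds than are shown below. What is called first, only, known or untested is meant among the compounds shown, and "the series" means these compounds.

For the measured compounds named here, compound 1 `COc1cc2c(Oc3ccc(NC(=O)c4cn(-c5ccccc5)nn4)cc3F)ccnc2cc1OCCCN1CCCC1` gives 280 nM in a functional assay on NCI-H460 cells (Homo sapiens) for cytotoxicity, read by MTT assay, with a stated time of 72 h (a lower number here means a stronger inhibitor, a higher number a weaker inhibitor), the lowest of the two numbers recorded, with compound 2 `COc1cc2c(Oc3ccc(NC(=O)c4cn(-c5c(C)cccc5C)nn4)cc3F)ccnc2cc1OCCCN1CCCC1` as its only neighbour at 1560 nM. Going by the values given here, the one measured step, a 5.6-fold higher number from compound 1 to compound 2 (0.75 log units; beyond the scatter), changes the aryl group on the triazole nitrogen and leaves the rest of the molecule untouched. Compound 3 `COc1cc2c(Oc3ccc(NC(=O)c4cn(-c5ccccc5)nn4)cc3F)ccnc2cc1OCCCN1CCN(C)CC1` differs from compound 1 at the opposite end of the structure: 4-methylpiperazin-1-yl in place of pyrrolidin-1-yl on a saturated chain carbon, three bonds along the chain from an oxygen on an aromatic ring. Among the compounds with values here, no measured step touches that chain amine, so the step to compound 2 says nothing direct about it; it only shows that the shared core tolerates a modest loss of potency without collapsing. With no comparison for the amine itself, the change from compound 1 to compound 3 is expected to stay small, and the estimate is that a 1.3-fold higher number from compound 1 to compound 3 (0.10 log units; within the scatter) falls inside or only slightly beyond the usual scatter. Compound 3 is therefore expected to give about 350 nM in this assay, with a plausible range from 120 nM to 1000 nM.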

Compound 3, half-maximal inhibitory concentration: 200 nM
Compound 3: middle estimate off by 1.8-fold (0.24 log units), on the high side; measured number inside the range.
By their numbers in this assay, from the lowest: compounds 3 and 1 (each within the scatter of the next); then compound 2.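

In this assay, for the compounds shown here, the first measured change at the chain amine, a 1.4-fold lower number from compound 1 to compound 3 (0.15 log units; within the scatter), shows that 4-methylpiperazin-1-yl can take the place of pyrrolidin-1-yl at this position without a change that can be told from the scatter. A six-membered non-aromatic ring with 2 hetero atoms and a five-membered non-aromatic ring with 1 hetero atom therefore cannot be separated here, whereas the change on the triazole nitrogen, a 5.6-fold higher number from compound 1 to compound 2 (0.75 log units; beyond the scatter), lies beyond the scatter. No measurement shown here offers an explanation for the result.

The two amines alone do not show whether this end of the molecule is free to vary more widely, or whether a morpholin-4-yl group, a dimethylamino group, a shorter chain or a chain ending in a hydroxyl group would also leave the number within the scatter. It also remains open whether the 2,6-dimethylphenyl group would give a step of similar size on the 4-methylpiperazin-1-yl compound, since that group is shown only with the pyrrolidin-1-yl chain.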